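A few compounds are considered here, and "the series" means these few. Any claim that something is new, unique, unknown or untested is made for them only; others in the source may bear on it.

Compound 2 `CCCCCCCCCCn1c(=O)n(C2OC(CO)[C@@H](O)[C@H]2O)c2nc(N)nc(O)c21` stands at the lowest of the two numbers recorded in a functional assay on the whole organism (B cells) with Mus musculus as the target; a lower number here means a smaller maximal response, a higher number a larger maximal response: compound 2 reaches 0%. Its nearest neighbour is compound 1 `Nc1nc(O)c2c(n1)n(C1OC(CO)[C@@H](O)[C@H]1O)c(=O)n2Cc1ccc(Cl)cc1`, which in this assay reaches 15%. Among the measured compounds shown here, the only recorded step, a number 15 percentage points lower from compound 1 to compound 2 (beyond the scatter), went with nonyl in place of 4-chlorophenyl on a saturated chain carbon bound to an aromatic nitrogen. Compound 3 `N#Cc1cccc(Cn2c(=O)n(C3OC(CO)[C@@H](O)[C@H]3O)c3nc(N)nc(O)c32)c1` turns that kind of change around: 3-cyanophenyl in place of nonyl on a saturated chain carbon bound to an aromatic nitrogen. Because a number 15 percentage points lower from compound 1 to compound 2 (beyond the scatter) accompanied the removal of an aromatic ring at that carbon, its return is expected to lift the maximal response by a number 12 percentage points higher from compound 2 to compound 3 (beyond the scatter). Compound 3 is therefore estimated at 12%, between 0% and 30%.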

Compound 3, largest response reached (reported as maximal response), in percent of the reference or control that the assay uses: 16%
Beside the measured number, compound 3's estimate is 4 percentage points below it, within the range that was stated.
By their numbers in this assay, from the lowest: compound 2; then compounds 1 and 3 (each within the scatter of the next).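

In this assay, a number 16 percentage points higher from compound 2 to compound 3 (beyond the scatter) shows that the drop seen with nonyl reverses when an aromatic ring returns on this saturated chain carbon. The a number 1 percentage points higher from compound 1 to compound 3 (within the scatter) adds that 3-cyanophenyl and 4-chlorophenyl cannot be told apart here, so the two differently substituted rings leave compound 1 and compound 3 level. Nothing available explains the difference between the chain and the rings.

Still open, as far as these compounds go, is whether an unsubstituted phenyl, or a phenyl carrying an amine or a carboxylic acid, would stay level with compound 1 and compound 3. A chain shorter than nonyl also remains to be placed.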